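The compounds below may be only part of what the source reports. "The series", "measured", "known", "first", "only" and "open" are said of these compounds alone.

Measured compounds: compound 1 `C/C=C/C=C/C(=O)N[C@H](C(=O)NCCCCCCCC)[C@@H](C)O` with 149000 nM; compound 2 `CCCCCCCCCCCCCCCCCCNC(=O)[C@@H](NC(=O)c1nccc2ccccc12)[C@@H](C)O` with 30800 nM; compound 3 `CCCCCCCCCCCCCCCCCCNC(=O)[C@@H](NC(=O)c1cc2ccccc2n1C)[C@@H](C)O` with 36400 nM, all in a functional assay on MCF7 cells (Homo sapiens) for cytotoxicity, read by MTT assay, with a stated time of 48 h; on this read-out lower numbers stand for stronger inhibition and higher numbers for weaker inhibition.

For the measured compounds named here, compound 3 stands second highest of the three numbers; its nearest neighbour is compound 2, and the only single-place step, a 1.2-fold higher number from compound 2 to compound 3 (0.07 log units; within the scatter), lies within the scatter. Compound 4 `C/C=C/C=C/C(=O)N[C@H](C(=O)NCCCCCCCCCCCCCCCCCC)[C@@H](C)O` arises from compound 3 by penta-1,3-dien-1-yl in place of 1-methyl-1H-indol-2-yl on a carbonyl carbon. Going by the values given here, no measured step matches this change. Compound 1 also carries penta-1,3-dien-1-yl on a carbonyl carbon but differs from compound 3 elsewhere, so its value and that of compound 3 only show that the pentadienyl compound gave the highest number seen. Compound 4 is therefore expected to give a somewhat higher number, a 1.8-fold higher number from compound 3 to compound 4 (0.25 log units; within the scatter), an estimate of 65000 nM ranging from 22000 nM to 190000 nM.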

Compound 4, half-maximal inhibitory concentration: 79600 nM
For compound 4 the middle estimate is 1.2-fold (0.09 log units) below the measured one; measured number inside the range.
By their numbers in this assay, from the lowest: compounds 2 and 3 (each within the scatter of the next); then compounds 4 and 1 (each within the scatter of the next).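

In this assay, replacing the ring groups on the carbonyl carbon has a modest effect that exceeds the scatter: penta-1,3-dien-1-yl gives a 2.2-fold higher number from compound 3 to compound 4 (0.34 log units; beyond the scatter) and a 2.6-fold higher number from compound 2 to compound 4 (0.41 log units; beyond the scatter), so 1-methyl-1H-indol-2-yl and isoquinolin-1-yl both read better than the open diene here. At the other end of the molecule, the decyl extension gives a 1.9-fold lower number from compound 1 to compound 4 (0.27 log units; within the scatter), which stays within the scatter. Nothing available explains either result.

On these data alone, whether an amine or a carboxylic acid on the acyl group would shift the number remains open. So does the effect of a longer chain than that of compound 4.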